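The compounds below may be only part of what the source reports. "The series", "measured", "known", "first", "only" and "open" are said of these compounds alone.

Measured so far:
compound 1, `CN(C)CCN(Cc1ccccc1)c1cccc(C(=O)N2CCc3ccc(OS(N)(=O)=O)cc3C2)c1`, gives 0% in an assay on HEK293 cells for inhibition of Steryl-sulfatase (Homo sapiens), tested at 0.1 uM; a higher number here means a stronger effect of the compound at the concentration tested, a lower number a weaker effect
compound 2, `CCCN(Cc1ccccc1)c1cccc(C(=O)N2CCc3ccc(OS(N)(=O)=O)cc3C2)c1`, gives 23.1% in this assay

Compound 2 stands highest of the two numbers in this assay; its nearest neighbour is compound 1, and the step of a number 23.1 percentage points higher from compound 1 to compound 2 (beyond the scatter) lies beyond the scatter.

Compound 3, `NS(=O)(=O)Oc1ccc2c(c1)CN(C(=O)c1cccc(N(CCCO)Cc3ccccc3)c1)CC2`, is not yet measured in this assay. It differs from compound 2 by hydroxy in place of hydrogen on a saturated chain carbon, three bonds along the chain from a nitrogen on an aromatic ring.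

Within the data shown here, only one measured step touches the same chain: the step from compound 1 to compound 2, a number 23.1 percentage points higher from compound 1 to compound 2 (beyond the scatter). Among the measured compounds shown here, that step exchanged dimethylamino for methyl on the chain; no measured step exchanges hydrogen for hydroxy anywhere, so there is no direct precedent for the change to compound 3. For the measured compounds named here, the one step that exists shows that what sits on this chain can move this assay by a modest amount, and the only substituted chain so far, in compound 1, gave the lower number.

Compound 3 is therefore expected to give 14% in this assay, with a range from 0% to 32%. This expectation corresponds to a step of a number 9.1 percentage points lower from compound 2 to compound 3 (within the scatter), a modest decrease that may well stay within the scatter.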

Compound 3, a percentage reported as inhibition, at one concentration (the size of the read-out at that concentration, not a potency): 25.8%
For compound 3 the middle estimate is 11.8 percentage points below the measured one; low and high end bracket the measured number.
By their numbers in this assay, from the lowest: compound 1; then compounds 2 and 3 (each within the scatter of the next).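

In this assay, hydroxy in place of hydrogen on the propyl chain, which gives the 3-hydroxypropyl group, makes a step of a number 2.7 percentage points higher from compound 2 to compound 3 (within the scatter), so the read-out does not separate these two chains at this place. The step of a number 25.8 percentage points higher from compound 1 to compound 3 (beyond the scatter), with hydroxymethyl in place of dimethylamino, shows that a substituent on the chain does not by itself bring the read-out down to that of compound 1: among the three compounds, only the dimethylamino chain stands apart, while the propyl and 3-hydroxypropyl chains stay within the scatter of each other. No measurement at hand bears on why the dimethylamino chain differs from the other two.

From the compounds shown here alone, it remains open whether a primary amine or a carboxylic acid at the end of the chain would behave like dimethylamino or like hydroxy, and whether a longer chain such as butyl or 4-hydroxybutyl would stay level with the propyl chain. Going by these compounds, the read-out comes from a single concentration, so whether compound 2 and compound 3 would differ in effect at any other concentration also remains open.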